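The source may report more compounds than this note shows. Statements on the series, on what has been measured and on what is new or still open speak of the compounds shown alone.

Of the compounds shown here, three have been tested in an ADME assay on microsomes from liver (Homo sapiens) for metabolic stability, using NADPH, with a stated time of 30 min, in the presence of a further agent that is not named here; on this read-out lower numbers stand for a less stable compound and higher numbers for a more stable compound. Compound 1 `CCOC(=O)C1c2c[nH]nc2CCN1S(=O)(=O)c1ccc(Cl)cc1` gives 1% in this assay. Within the data shown here, compound 2 `O=S(=O)(c1ccc(Cl)cc1)N1CCc2n[nH]cc2C1CO` gives 84%; the step of a number 83 percentage points higher from compound 1 to compound 2 (beyond the scatter) is the only one between compounds that differ in a single place. Compound 3 `O=S(=O)(c1ccc(Cl)cc1)N1Cc2c[nH]nc2CC1c1nccs1` gives 54%, the second highest of the three numbers, clearly under compound 2 and well above compound 1.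

Compound 4 `O=S(=O)(c1ccc(Cl)cc1)N1Cc2c[nH]nc2CC1c1ccccc1` is not yet measured. It differs from compound 3 in one place: phenyl in place of 1,3-thiazol-2-yl on a saturated ring carbon. Among the measured compounds shown here, no measured step exchanges one aromatic ring for another on this carbon; the step from compound 1 to compound 2 swaps groups of a different kind, so it gives no direct guide, and the change for compound 4 is modest compared with it. The expected step is therefore a small one, a number 14 percentage points lower from compound 3 to compound 4 (beyond the scatter), perhaps downward, within or just beyond the scatter. Compound 4 is estimated to give 40%, between 15% and 70%.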

Compound 4, percent of the compound remaining: 5%
Beside the measured number, compound 4's estimate is 35 percentage points above it; measured number outside the range, below it.
By their numbers in this assay, from the lowest: compounds 1 and 4 (each within the scatter of the next); then compound 3; then compound 2.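

The exchange of 1,3-thiazol-2-yl for phenyl on this saturated ring carbon brings a number 49 percentage points lower from compound 3 to compound 4 (beyond the scatter) in this assay, so the read-out is sensitive even to which aromatic ring sits at this place. Among these compounds, until now, the only step between compounds differing in one place was between two quite different groups, ethoxycarbonyl and hydroxymethyl; here, two aromatic rings of similar size prove far from interchangeable. Nothing measured here explains why these two rings give such different numbers.

The compounds shown leave open whether another aromatic ring, such as pyridyl or oxazolyl, would stay closer to compound 3 or fall closer to compound 4. They also do not show how an amine or a carboxylic acid on this carbon would behave in this assay.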